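A few compounds are considered here, and "the series" means these few. Any claim that something is new, unique, unknown or untested is made for them only; others in the source may bear on it.

Within the data shown here, compound 1, with the structure `O=C1COc2ccc(-c3cnc(Cl)c(NS(=O)(=O)c4ccc(F)cc4)c3)cc2N1c1ccccc1`, is one of three compounds measured in a functional assay on HeLa cells (Homo sapiens) for antiproliferative activity, read by MTT assay, with a stated time of 72 h; on this read-out higher numbers stand for weaker inhibition and lower numbers for stronger inhibition. In this assay compound 1 gives 10300 nM. Compound 2, of structure `COc1ccc(N2C(=O)COc3ccc(-c4ccc(O)cc4)cc32)cc1`, gives 16400 nM in this assay, and compound 3, of structure `COc1ncc(-c2ccc3c(c2)N(C2CC2)C(=O)CO3)cc1NS(=O)(=O)c1ccc(F)cc1`, gives 6030 nM. The three numbers lie within the usual scatter of one another, so none of the three compounds can be set apart from the others on these data; compound 1 simply sits among them.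

Compound 4, of structure `COc1ccc(N2C(=O)COc3ccc(-c4cnc(Cl)c(NS(=O)(=O)c5ccc(F)cc5)c4)cc32)cc1`, has not yet been measured in this assay. It differs from compound 1 in a single place: methoxy in place of hydrogen on an aromatic carbon. Among the measured compounds shown here, no measured pair in this set shows the same change on its own, so no direct precedent for its size exists here. Compound 2 carries the same methoxy group and gives 16400 nM, a number in the same region as compound 1, which suggests the change need not move the result far.

Compound 4 is therefore expected to fall close to compound 1, with the estimated step of a 1.2-fold higher number from compound 1 to compound 4 (0.07 log units; within the scatter) not beyond the scatter. The estimate for compound 4 in this assay is 12000 nM, with a range from 5000 nM to 30000 nM.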

Compound 4, half-maximal inhibitory concentration: 8320 nM
Compound 4: middle estimate off by 1.4-fold (0.16 log units), on the high side, within the range that was stated.
By their numbers in this assay, from the lowest: compounds 3, 4, 1 and 2 (each within the scatter of the next, the first and the last beyond it).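

Read directly for the first time, the change from phenyl to 4-methoxyphenyl gives, in this assay, a 1.2-fold lower number from compound 1 to compound 4 (0.09 log units; within the scatter). Among these compounds, the aromatic carbon para to a large group therefore carries a methoxy group in place of hydrogen with no shift that can be told apart from repeat measurement, a reading that the earlier compounds, none of which formed a pair differing in this one place, could not give. This holds for one pair on the core of compound 1 only, and nothing available here bears on why the step is so small.

The compounds shown leave open whether this position stays as undemanding with other groups, such as an amine, a carboxylic acid, a fluorine atom or a longer chain like butoxy, any of which might move the number beyond the scatter or might leave it where it is. They also leave open whether methoxy in place of hydrogen would give a similarly small step on a core carrying a different group on the ring nitrogen or a different substituent on the sulfonamide's aromatic ring.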